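Imidazoline ethers: heteroaryl swap toward compound 3

A few compounds are considered here, and "the series" means these few. Any claim that something is new, unique, unknown or untested is made for them only; others in the source may bear on it.

Measured so far:
compound 1 `c1cncc(-c2ccccc2OCC2=NCCN2)c1` gives 2 nM in a functional assay for activation of Alpha-1A adrenergic receptor (Homo sapiens), read by calcium flux; on this read-out higher numbers stand for an effect only at larger amounts of compound and lower numbers for an effect already at smaller amounts.
compound 2 `c1c[nH]c(-c2ccccc2OCC2=NCCN2)c1` gives 1.26 nM in this assay.

Compound 2 holds the lower of the two numbers, but the step of a 1.6-fold lower number from compound 1 to compound 2 (0.20 log units; within the scatter) sits within the scatter, so no order between compound 1 and compound 2 can be read from it. Compound 3 `c1ccc(-c2ccns2)c(OCC2=NCCN2)c1` differs from compound 2 by 1,2-thiazol-5-yl in place of 1H-pyrrol-2-yl on an aromatic carbon. Among the measured compounds shown here, the only measured step, a 1.6-fold lower number from compound 1 to compound 2 (0.20 log units; within the scatter), also exchanged one aromatic ring for another at the same carbon and left the number essentially unchanged; it bears on the present change, though neither measured compound carries a ring with two hetero atoms or with sulfur. The expectation for this assay is therefore a step of a 2.4-fold higher number from compound 2 to compound 3 (0.38 log units; beyond the scatter), most likely a somewhat higher number but not clearly beyond the scatter. Compound 3 is estimated at 3 nM, with a range from 0.8 nM to 12 nM.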

Compound 3, half-maximal effective concentration: 5.01 nM
The estimate for compound 3 lay 1.7-fold (0.22 log units) below the measured number; the range from low to high includes it.
By their numbers in this assay, from the lowest: compounds 2 and 1 (each within the scatter of the next); then compound 3.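

In this assay, the aromatic carbon ortho to a group of 7 heavy atoms now shows that the number can respond to the ring placed there, with 1,2-thiazol-5-yl separating from both earlier rings (a 4.0-fold higher number from compound 2 to compound 3 (0.60 log units; beyond the scatter)) (a 2.5-fold higher number from compound 1 to compound 3 (0.40 log units; beyond the scatter)). The earlier exchange of pyridin-3-yl for 1H-pyrrol-2-yl stayed within the scatter, so this position does not accept every aromatic ring equally, although both new steps are modest. Nothing at hand gives a reason for the shift.

Between 1H-pyrrol-2-yl and 1,2-thiazol-5-yl, the sulfur, the second ring hetero atom and the hydrogen-bond donor and acceptor counts all change together, and these compounds cannot separate them. Also open, from the compounds shown here alone, is how the number responds at this carbon to a group without an aromatic ring, such as an amine, a carboxylic acid or a longer alkyl chain.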